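Aromatic bicycle replacing the sulfone chain on the ether

This account rests on a few compounds, and the source may have more. Where it says the series, first, only, none or still open, it means among the compounds named here.

Measured so far:
compound 1, `CCS(=O)(=O)CCOc1cc(C)c(-c2cccc(COc3ccc4c(c3)OC[C@H]4CC(=O)O)c2)c(C)c1`: 14 nM
compound 2, `Cc1c(C)c(-c2cccc(COc3ccc4c(c3)OC[C@H]4CC(=O)O)c2)c(C)c(C)c1OC1CCS(=O)(=O)CC1`: 29 nM

In a functional assay on CHO cells for agonist activity at Free fatty acid receptor 1 (Homo sapiens), read by FLIPR and calcium flux, with a stated time of 90 s, in the presence of a further agent that is not named here (a lower number here means that less compound is needed, a higher number that more compound is needed for the effect), compound 1 gives 14 nM, the lowest of the two numbers in hand. Within the data shown here, compound 2, the only neighbour, gives 29 nM in this assay, a higher number by a margin beyond the scatter; the two compounds differ in more than one place, so no single step can be drawn between them.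

Compound 3, `Cc1cc(OCc2cccc3nccn23)cc(C)c1-c1cccc(COc2ccc3c(c2)OC[C@H]3CC(=O)O)c1`, differs from compound 1 in one place: a group of 9 heavy atoms (7 carbon, 2 nitrogen; one five-membered aromatic ring with 2 hetero atoms, one six-membered aromatic ring with 1 hetero atom) in place of a group of 6 heavy atoms (3 carbon, 2 oxygen, 1 sulfur; no ring), on a saturated chain carbon bound to an oxygen on an aromatic ring. Among the measured compounds shown here, no measured pair covers a change of this kind, so the direction of the step in this assay cannot be read from the two numbers in hand. The expected step from compound 1 to compound 3 is a small one, a 1.4-fold higher number from compound 1 to compound 3 (0.15 log units; within the scatter), not clearly beyond the scatter in either direction. Compound 3 is expected to give 20 nM in this assay, within a range from 5 nM to 80 nM.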

Compound 3, half-maximal effective concentration in the Free fatty acid receptor 1 assay: 17 nM
Compound 3: middle estimate off by 1.2-fold (0.07 log units), on the high side; low and high end bracket the measured number.
By their numbers in the Free fatty acid receptor 1 assay, from the lowest: compounds 1, 3 and 2 (each within the scatter of the next, the first and the last beyond it).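

In the Free fatty acid receptor 1 assay, exchanging the (ethylsulfonyl)methyl group for the aromatic group with a five-membered and a six-membered ring (a 1.2-fold higher number from compound 1 to compound 3 (0.08 log units; within the scatter)) shows that this saturated chain carbon bound to an oxygen on an aromatic ring can carry a larger, ring-bearing group with no separation between the two compounds. The sulfonyl group is therefore not required for the number in this assay, at least in this one pair. In a physicochemical assay for lipophilicity, read by HPLC, at pH 7.4 (a higher number here means a more lipophilic compound, a lower number a more polar compound), compound 1 gives 2.73 and compound 3 gives 3.8 as its value, so this same exchange does separate the pair (a number 1.07 log units higher from compound 1 to compound 3 (beyond the scatter)).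

The compounds shown leave open how a single ring such as pyridine, or an amine such as morpholine, would read at this place in either the Free fatty acid receptor 1 assay or the physicochemical assay. Whether both rings of the new group are needed also cannot be read from this one pair.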